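Replacing hydroxy in compound 1: an estimate for compound 3

A few compounds are considered here, and "the series" means these few. Any claim that something is new, unique, unknown or untested is made for them only; others in the source may bear on it.

Compound 1 `CC(=O)SCCC(CCCCC(=O)O)SC(C)=O` - "not active" (no number reported)
Compound 2 `O=C(CCCCC(S)CCS)Nc1ccc(F)cc1` - 8.11%

In a functional assay on HO8910 cells (Homo sapiens) for inhibition, read by MTT assay, with a stated time of 24 h, tested at 0.1 ug/mL (on this read-out higher numbers stand for more inhibition of growth at the one concentration tested and lower numbers for less inhibition of growth), compound 1 has no single number and stands only as "not active" (no number reported) in the record. Compound 3 `CC(=O)SCCC(CCCCC(=O)Nc1cccc(Cl)c1)SC(C)=O` differs from compound 1 in one place, with (3-chlorophenyl)amino in place of hydroxy on a carbonyl carbon and nothing else changes. For the measured compounds named here, no measured pair shows the size of such a change. Going by the values given here, a small upward step in inhibition is expected, resting only on compound 2 at 8.11% as the sole number available. Compound 3 is estimated at 10% in this assay, with an expected range from 2% to 25% for the coming measurement.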

Compound 3, percent growth inhibition at one concentration: 0.27%
Beside the measured number, compound 3's estimate is 9.7 percentage points above it; measured number below the stated range.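

In this assay, for the compounds shown here, compound 1 stands as "not active" (no number reported) and compound 3 gives 0.27% so no step between compound 1 and compound 3 can be read. On these data alone, the size of the change from hydroxy to (3-chlorophenyl)amino stays open. No evidence bears on this result.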